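The compounds below may be only part of what the source reports. "The series", "measured", "known", "first", "only" and "open" are said of these compounds alone.

Series notes. In an assay on isolated protein for displacement of a labelled ligand from secreted frizzled-related protein 1 (Homo sapiens), read by fluorescence polarization, with a stated time of 30 min (a higher number here means a weaker inhibitor, a lower number a stronger inhibitor), compound 1 `CN(C)c1ccc(C(=O)N2CCC(NS(=O)(=O)c3cc(S(=O)(=O)c4ccccc4)ccc3C(F)(F)F)CC2)cc1` gives 300 nM, the highest number of the three measured. Compound 2 `O=C(O)c1ccc(S(=O)(=O)N2CCC(NS(=O)(=O)c3cc(S(=O)(=O)c4ccccc4)ccc3C(F)(F)F)CC2)cc1` gives 20 nM and compound 3 `N#Cc1cccc(S(=O)(=O)N2CCC(NS(=O)(=O)c3cc(S(=O)(=O)c4ccccc4)ccc3C(F)(F)F)CC2)c1` gives 90 nM. The steps of a 15-fold lower number from compound 1 to compound 2 (1.18 log units; beyond the scatter) and a 3.3-fold lower number from compound 1 to compound 3 (0.52 log units; beyond the scatter) both exchanged the (4-(dimethylamino)phenyl)carbonyl on the ring amine nitrogen for an arylsulfonyl group, and a 4.5-fold higher number from compound 2 to compound 3 (0.65 log units; beyond the scatter) separates the two aryl groups on the sulfonyl sulfur. Compound 4 `CC(C)(C)OC(=O)N1CC[C@@H](C(=O)N2CCC(NS(=O)(=O)c3cc(S(=O)(=O)c4ccccc4)ccc3C(F)(F)F)CC2)C1` instead keeps the carbonyl: 1-(tert-butoxycarbonyl)pyrrolidin-3-yl in place of 4-(dimethylamino)phenyl on a carbonyl carbon. Among the measured compounds shown here, no measured step alters the carbonyl substituent alone, so the two carbonyl-to-sulfonyl steps bear on compound 4 only loosely, and no carbonyl-retaining change has been measured. The step of a 1.3-fold higher number from compound 1 to compound 4 (0.12 log units; within the scatter) is therefore expected to be small and of uncertain direction. Compound 4 is expected at 400 nM, within 130 nM to 1300 nM.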

Compound 4, half-maximal inhibitory concentration: 50 nM
Compound 4: the middle estimate sits 8.0-fold (0.90 log units) above what was measured; the measured number lies below the stated range.
By their numbers in this assay, from the lowest: compound 2; then compounds 4 and 3 (each within the scatter of the next); then compound 1.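

The carbonyl on the ring amine nitrogen can stay while the number in this assay still falls: the change to 1-(tert-butoxycarbonyl)pyrrolidin-3-yl gives a 6.0-fold lower number from compound 1 to compound 4 (0.78 log units; beyond the scatter) and so moves the value with the substituent on that carbonyl carbon alone. An aromatic ring on this carbonyl is therefore not required for the lower number. No available evidence accounts for this step.

Open, on these data alone, is whether the lower number persists with a free secondary amine on the pyrrolidine in place of the tert-butoxycarbonyl group. As far as these compounds go, the contribution of the defined stereocentre also remains open.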